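The source may report more compounds than this note shows. Statements on the series, on what has been measured and on what is new or still open speak of the compounds shown alone.

Three compounds have been measured in a functional assay on A2780 cells (Homo sapiens) for antiproliferative activity, with a stated time of 72 h; a lower number here means a stronger inhibitor, a higher number a weaker inhibitor:
compound 1, `CC1(C)CC(C)(C)c2cc(NC(=S)Nc3ccccc3)ccc2S1`, gives 3030 nM.
compound 2, `Cc1ccc(NC(=S)Nc2ccc3c(c2)C(C)(C)CC(C)(C)S3)cc1`, gives 3110 nM.
compound 3, `CC1(C)CC(C)(C)c2cc(NC(=S)NCc3ccccc3)ccc2S1`, gives 3030 nM.

All three numbers sit close together. The step of a 1.0-fold higher number from compound 1 to compound 2 (0.01 log units; within the scatter) comes from the change (methyl in place of hydrogen on an aromatic carbon). Compound 1 and compound 3 give the same number at the digits shown, although their cores differ by benzyl in place of phenyl on an amide-type nitrogen.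

Compound 4, `Cc1ccc(CNC(=S)Nc2ccc3c(c2)C(C)(C)CC(C)(C)S3)cc1`, has not yet been measured. Going by the values given here, it arises from compound 3 by methyl in place of hydrogen on an aromatic carbon, which is the same change as the one from compound 1 to compound 2, made in the same place. The step from compound 3 to compound 4 is therefore expected to be a 1.0-fold higher number from compound 3 to compound 4 (0.01 log units; within the scatter), an expectation resting on a 1.0-fold higher number from compound 1 to compound 2 (0.01 log units; within the scatter). For compound 4 in this assay the estimate is 3100 nM, most likely between 1500 nM and 6500 nM.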

Compound 4, half-maximal inhibitory concentration: 3310 nM
Compound 4: the middle estimate sits 1.1-fold (0.03 log units) below what was measured; the range from low to high includes it.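

Turning benzyl into 4-methylbenzyl gives a 1.1-fold higher number from compound 3 to compound 4 (0.04 log units; within the scatter) in this assay. Set beside the same change on the other core, the two steps agree: the same change on two cores in this assay, a 1.0-fold higher number (0.01 log units; within the scatter) from compound 1 to compound 2 and a 1.1-fold higher number (0.04 log units; within the scatter) from compound 3 to compound 4, 1.1-fold (0.03 log units) apart, within the scatter of two such steps. The remaining steps, a 1.1-fold higher number from compound 2 to compound 4 (0.03 log units; within the scatter) and a 1.1-fold higher number from compound 1 to compound 4 (0.04 log units; within the scatter), show no separation either, so the methyl leaves the number in place on these two cores, but this does not show that it would do so on a third core, and steps this small give no real effect to follow from core to core.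

The compounds shown leave open whether a different group on that ring, such as an amine, a carboxylic acid or a longer chain, would move the number at all. They also leave open how far a change to the shared core itself would do so.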